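Carbamate series: cyanoaryl leaving group variation

This account rests on a few compounds, and the source may have more. Where it says the series, first, only, none or still open, it means among the compounds named here.

Two compounds of this carbamate series have numbers in an assay on isolated protein for inhibition of Monoglyceride lipase (Rattus norvegicus), read by fluorescence, with stated times of 15 min and 3 h; a higher number here means a weaker inhibitor, a lower number a stronger inhibitor. Compound 1 `N#Cc1ccnc(OC(=O)N2CCC(C(c3ccccc3)c3ccccc3)CC2)c1` gives 20.1 nM, and compound 2 `N#Cc1cccc(OC(=O)N2CCC(C(c3ccc(Cl)cc3)c3ccc(Cl)cc3)CC2)c1` gives 32.5 nM. Compound 1 stands at the lower of the two numbers, but the gap to compound 2 is within the scatter, so no order between them can be read from this.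

Compound 3 `Cc1cc(C#N)cc(OC(=O)N2CCC(C(c3ccccc3)c3ccccc3)CC2)c1` is not yet measured. It differs from compound 1 by 3-cyano-5-methylphenyl in place of 4-cyanopyridin-2-yl on an oxygen next to a carbonyl group. Going by the values given here, no measured pair shows this exact change, so the direction is uncertain. Compound 2, which also carries a cyanophenyl group on the carbamate oxygen, gives 32.5 nM, a number close to that of compound 1, which suggests the exchange of the aromatic ring leaves the number near its present level. A step of no more than the scatter, if anything towards a somewhat higher number, is expected as a 1.7-fold higher number from compound 1 to compound 3 (0.24 log units; within the scatter). Compound 3 is therefore estimated at 35 nM, within 12 nM to 100 nM.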

Compound 3, half-maximal inhibitory concentration: 150 nM
For compound 3 the middle estimate is 4.3-fold (0.63 log units) below the measured one, and the stated range ends below it.
By their numbers in this assay, from the lowest: compounds 1 and 2 (each within the scatter of the next); then compound 3.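

In this assay the step is a 7.5-fold higher number from compound 1 to compound 3 (0.87 log units; beyond the scatter) and shows that this place, on an oxygen next to a carbonyl group, is not indifferent to the aromatic group it carries. A nitrile on the ring does not by itself keep the number near that of compound 1. The two groups differ at once in the ring hetero atom, the methyl and the numbering of the cyano group, so the step belongs to the whole exchange and to none of these parts alone. Nothing at hand bears on why the number rises.

Open, going by these compounds, is which of these differences carries the step, and a plain 3-cyanophenyl group or a methyl-bearing 4-cyanopyridin-2-yl group would separate them. Also open, on these data alone, is how a trifluoromethyl or a carboxylic acid in place of the nitrile would read on the same ring.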